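Thiourea carboxylic acids: aryl swap at the saturated ring carbon

This account rests on a few compounds, and the source may have more. Where it says the series, first, only, none or still open, it means among the compounds named here.

Measured so far:
- compound 1 `O=C(O)CCC1=C(c2ccc(Cl)cc2)NC(=S)NC1c1ccccc1O`: 9.61%
- compound 2 `O=C(O)CCC1=C(c2ccccc2)NC(=S)NC1c1ccccc1O`: 33%

Compound 1 gives the lowest of the two numbers in a functional assay on the whole organism (strain Albino) for inhibition, with Rattus norvegicus as the target, with a stated time of 1 h, at a dose of 20 mg/kg by the oral route; on this read-out higher numbers stand for more inhibition at the one dose given (going by the name of the read-out) and lower numbers for less inhibition; its nearest neighbour is compound 2, reached by a number 23.4 percentage points higher from compound 1 to compound 2 (beyond the scatter), a change of hydrogen in place of chloro on an aromatic carbon.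

Compound 3 `O=C(O)CCC1=C(c2ccc(Cl)cc2)NC(=S)NC1c1ccco1` keeps the chloro-bearing ring of compound 1 and differs from it only by furan-2-yl in place of 2-hydroxyphenyl on a saturated ring carbon. For the measured compounds named here, no measured step touches this position: the single step recorded in this assay concerns the chloro substituent on the other aromatic ring and so says nothing about the exchange of the 2-hydroxyphenyl group for furan-2-yl. Going by the values given here, what can be carried over is only the level of compound 1 itself, which is low, leaving little room to fall and no measured precedent to rise.

The expectation for compound 3 is therefore a step of about a number 4.4 percentage points higher from compound 1 to compound 3 (within the scatter), not clearly beyond the scatter in either direction. Compound 3 is estimated at 14% in this assay, with a range from 0% to 38%.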

Compound 3, a percentage reported as inhibition, in the whole organism at one dose (the size of the read-out at that dose, not a potency): 30.4%
For compound 3 the middle estimate is 16.4 percentage points below the measured one, within the range that was stated.
By their numbers in this assay, from the lowest: compound 1; then compounds 3 and 2 (each within the scatter of the next).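

In this assay, the saturated ring carbon next to the ring nitrogen responds to the group it carries: with the 4-chlorophenyl group held constant, furan-2-yl in place of 2-hydroxyphenyl gives a number 20.8 percentage points higher from compound 1 to compound 3 (beyond the scatter), a step beyond the scatter. For the compounds shown here, until now the only measured step was on the other aromatic ring, hydrogen in place of chloro, with a number 23.4 percentage points higher from compound 1 to compound 2 (beyond the scatter), so the low level of compound 1 can now be seen to shift through a change at either of two places, and a group with no hydrogen-bond donor at this carbon still gives a reading above that of compound 1.

Open, going by these compounds, is whether the furan-2-yl exchange gives a similar step when hydrogen stands in place of chloro, as in the core of compound 2, or whether the two changes overlap rather than add. Also open, on these data alone, is how far this carbon accepts other groups, such as thiophen-2-yl, unsubstituted phenyl or a 2-methoxyphenyl group, and whether the 2-carboxyethyl group can give way to a longer chain or an amide.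

No measurement at hand accounts for the step at this carbon.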